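The compounds below may be only part of what the source reports. "The series", "measured", "known", "first", "only" and "open" are said of these compounds alone.

Compound 2 `CC(C)c1ccccc1/C=C/C(=O)c1ccccc1` is the starting point of this piece. In an ADME assay on cells (Epithelial cell, Homo sapiens) for cytotoxicity, read by MTT assay, with a stated time of 44 h (on this read-out lower numbers stand for stronger inhibition and higher numbers for weaker inhibition), compound 2 gives only a limit, > 46000 nM, and not a number. Its neighbour compound 1 `CCc1ccccc1/C=C/C(=O)c1ccccc1` also reaches only a limit in this assay, namely > 50000 nM. Among the compounds with values here, the one measured step, a step that the two limits leave unreadable from compound 1 to compound 2, is therefore unreadable; both of its ends are limits, so nothing can be said about whether adding a methyl on the saturated chain carbon changed cytotoxicity at all.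

Compound 3 `O=C(/C=C/c1ccccc1Cl)c1ccccc1` carries the change (chloro in place of isopropyl on an aromatic carbon). Within the data shown here, no measured step shows what this exchange does in this assay, and the only step known at all cannot be read. There is thus no basis for expecting a move beyond the scatter in either direction. The step expected in this assay is a step that the limit leaves unreadable from compound 2 to compound 3, which amounts to no real change. Compound 3 is therefore estimated to give about 50000 nM in this assay, within a range from 20000 nM to 120000 nM, and it is expected that most often only a limit will again be reported.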

Compound 3, half-maximal inhibitory concentration: > 50000 nM
Compound 3 ended at the assay's limit (the forecaster's own chance of this, stated with the estimate: 70%); the middle value lies on the limit itself.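

In this assay compound 3 gives only a limit, > 50000 nM. The steps linking it to compound 1 and compound 2 therefore cannot be read. The compounds shown leave open whether exchanging ethyl, isopropyl and chloro on the aromatic carbon changes cytotoxicity at all, and what actual number any of the three would give.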